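The compounds below may be only part of what the source reports. "The series", "measured", "known", "first", "only" and "open" are said of these compounds alone.

Of the compounds shown here, three have so far been tested in a functional assay on MDA-MB-231 cells (Homo sapiens) for antiproliferative activity, read by XTT assay, with a stated time of 48 h; on this read-out lower numbers stand for stronger inhibition and higher numbers for weaker inhibition. Compound 3 `CC(=O)OC[C@H]1O[C@@H](n2cc(CN(c3ccc(C)cc3)S(=O)(=O)c3ccccc3)nn2)[C@H](OC(C)=O)[C@@H](OC(C)=O)[C@@H]1OC(C)=O` gives 180000 nM. Compound 1 `CCCCCCN(Cc1cn([C@@H]2O[C@H](COC(C)=O)[C@@H](OC(C)=O)[C@H]2OC(C)=O)nn1)S(C)(=O)=O` gives 225000 nM in this assay, and the gap between compound 3 and compound 1 lies within the scatter, so neither can be called the more active of the two. Compound 2 `CCS(=O)(=O)N(Cc1cn([C@@H]2O[C@H](COC(C)=O)[C@@H](OC(C)=O)[C@H](OC(C)=O)[C@H]2OC(C)=O)nn1)c1ccc(Cl)cc1` returns only a limit of the assay, > 250000 nM, and not a number. Compound 3 thus holds the lower of the two numbers seen, with compound 1 close beside it, while for compound 2 there is only (the limit of > 250000 nM in this assay, at which 1 of the 3 values shown sits).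

Compound 4 `CC(=O)OC[C@H]1O[C@@H](n2cc(CN(c3ccc(Cl)cc3)S(=O)(=O)c3ccccc3)nn2)[C@H](OC(C)=O)[C@@H](OC(C)=O)[C@@H]1OC(C)=O` has not been measured. It differs from compound 3 in a single place: chloro in place of methyl on an aromatic carbon. For the measured compounds named here, no measured pair here shows this exchange on its own, so its effect cannot be read from the numbers at hand. Going by the values given here, with the two known numbers close together and the exchange confined to one substituent on the aromatic ring, the expected 1.1-fold higher number from compound 3 to compound 4 (0.05 log units; within the scatter) is judged to stay within the scatter, in no clear direction. Compound 4 is therefore estimated at 200000 nM in this assay, with a range from 90000 nM to 450000 nM, and with a fair chance that only a limit is reported.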

Compound 4, half-maximal inhibitory concentration: 135000 nM
Compound 4: the middle estimate sits 1.5-fold (0.17 log units) above what was measured; the measured number falls inside the stated range.
By their numbers in this assay, from the lowest: compounds 4, 3 and 1 (each within the scatter of the next). At a limit, above all of these: compound 2.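

For the compounds shown here, this is the first direct reading of the 4-methylphenyl to 4-chlorophenyl change, with the substituent on an aromatic carbon, para to a large group. In this assay, chloro in place of methyl gives a 1.3-fold lower number from compound 3 to compound 4 (0.12 log units; within the scatter), so the two compounds cannot be told apart, and this one exchange leaves the read-out unchanged within the usual scatter. Phenyl in place of ethyl on the sulfonyl sulfur gives an at least 1.8-fold lower number from compound 2 to compound 4 (0.26 log units; that floor lies within the scatter), so even this floor does not separate the pair, and compound 2 is known only through a limit: the limit of > 250000 nM in this assay, at which 1 of the 4 values shown sits.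

Going by these compounds alone, with methyl and chloro as the only two groups compared directly at this place, it remains open whether a quite different group there, such as an amine or a carboxylic acid, would shift the number beyond the scatter. As far as these compounds go, it also remains open whether a change elsewhere, such as hydroxyl groups in place of the acetate groups on the shared core, would matter more than any exchange on this aromatic ring.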